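Inverting one ring stereocentre of compound 1

This account rests on a few compounds, and the source may have more. Where it says the series, first, only, none or still open, it means among the compounds named here.

Measured so far in an assay on HEK293 cells for antagonist activity at transient receptor potential cation channel subfamily V member 3 (Homo sapiens), read by FLIPR and calcium flux; on this read-out lower numbers stand for stronger inhibition and higher numbers for weaker inhibition:
Compound 1 `O[C@@]1(c2ccccn2)CC[C@@H](c2ccc(C(F)(F)F)cc2)C1` gives 240 nM.
Compound 2 `O[C@H](c1ccccn1)[C@]1(c2ccc(C(F)(F)F)cc2)C[C@@H](O)C1` gives 1870 nM.

Compound 1 holds the lower of the two numbers; compound 2 sits well higher, but the pair is not a single-change step, so the two values are noted without further reading. Compound 3 `O[C@@]1(c2ccccn2)CC[C@H](c2ccc(C(F)(F)F)cc2)C1` keeps every atom and bond of compound 1; (the two compounds have the same atoms and bonds and differ only in configuration as drawn: 1 of 2 stereo elements differ; a stereocentre at a saturated ring carbon is drawn R in compound 1 and S in compound 3). Among the compounds with values here, no measured pair shows what this inversion does in this assay, so the direction is open. A moderate weakening is taken as the working guess, with a range wide enough to include no change beyond the scatter. Compound 3 is expected at 600 nM, between 150 nM and 3000 nM. The step from compound 1 to compound 3 is thus estimated as a 2.5-fold higher number from compound 1 to compound 3 (0.40 log units; beyond the scatter).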

Compound 3, antagonist equilibrium constant: 610 nM
Compound 3: middle estimate off by 1.0-fold (0.01 log units), on the low side, within the range that was stated.
By their numbers in this assay, from the lowest: compound 1; then compound 3; then compound 2.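

Within the data shown here, this is the first single-change step: in this assay, the stereocentre at a saturated ring carbon affects the read-out, with a 2.5-fold higher number from compound 1 to compound 3 (0.41 log units; beyond the scatter) as R becomes S. Compound 3 remains measurable, so the inversion weakens inhibition without abolishing it. The step can be assigned to this one stereocentre alone because no atom or bond changes: the fact that compounds 1 and 3 differ only in the configuration as drawn

As far as these compounds go, the effect of inverting the other stereo element of compound 1 remains open. Also open, from the compounds shown here alone, is whether the R preference would persist with an amine in place of the hydroxyl.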